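The source may report more compounds than this note shows. Statements on the series, on what has been measured and on what is new or still open speak of the compounds shown alone.

Measured compounds:
compound 1 `COc1ccc(N(C)c2nc(C)nc3ccccc23)cc1C(=O)OCC[Se]C#N` 2960 nM
compound 2 `COc1ccc(N(C)c2nc(C)nc3ccccc23)cc1[Se]C` 3 nM
compound 3 `COc1ccc(N(C)c2nc(C)nc3ccccc23)cc1OCC[Se]C#N` 19 nM

In a functional assay on LoVo cells (Homo sapiens) for inhibition, read by MTT assay, with a stated time of 48 h (on this read-out higher numbers stand for weaker inhibition and lower numbers for stronger inhibition), compound 3 stands second highest of the three numbers; its nearest neighbour is compound 2, with a 6.3-fold higher number from compound 2 to compound 3 (0.80 log units; beyond the scatter), and its furthest is compound 1, with a 160-fold lower number from compound 1 to compound 3 (2.19 log units; beyond the scatter). Compound 4 `COc1ccc(N(C)c2nc(C)nc3ccccc23)cc1[Se]C#N` differs from compound 3 by a group of 3 heavy atoms (1 carbon, 1 nitrogen, 1 selenium; no ring) in place of a group of 6 heavy atoms (3 carbon, 1 nitrogen, 1 oxygen, 1 selenium; no ring), on an aromatic carbon. Going by the values given here, no measured step covers this exact change. Compound 2, which carries a small group directly on the same aromatic carbon, gives 3 nM in this assay, and the step from compound 1 to compound 3 was large. A small group attached directly, as in compound 2, is therefore expected to give a modest lower number, a 2.4-fold lower number from compound 3 to compound 4 (0.38 log units; beyond the scatter). Compound 4 is estimated at 8 nM, in the range 2 nM to 40 nM.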

Compound 4, half-maximal inhibitory concentration: 73 nM
Estimate against measurement, compound 4: 9.1-fold (0.96 log units) below; measured number outside the range, above it.
By their numbers in this assay, from the lowest: compound 2; then compound 3; then compound 4; then compound 1.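

In this assay, the group on selenium matters as well as its size: with selenium on the aromatic carbon in both compounds, cyano in place of methyl gives a 24-fold higher number from compound 2 to compound 4 (1.39 log units; beyond the scatter). Small size alone therefore does not secure the lowest numbers, as the longer chain of compound 3 compares favourably, with a 3.8-fold higher number from compound 3 to compound 4 (0.58 log units; beyond the scatter), although the direct attachment still far outperforms the ester chain, with a 41-fold lower number from compound 1 to compound 4 (1.61 log units; beyond the scatter). Nothing shown accounts for these differences. The compounds shown leave open how an ethyl group on selenium would compare with methyl, and whether an amine in place of the nitrile on the chain of compound 3 would change the number.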